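Reversing an amide and changing its side chain

The source may hold more compounds than are shown below. What is called first, only, known or untested is meant among the compounds shown, and "the series" means these compounds.

Compound 3 `Cc1cc(NC(=O)C2(F)CCNCC2)nn1Cc1cc(Cl)cc2cc(-c3ccccc3)oc12` gives 39.8 nM in an assay on CHO-K1 cells for displacement of a labelled ligand from prostaglandin E2 receptor EP1 subtype (Homo sapiens), read by scintillation counting, with a stated time of 45 min; a higher number here means a weaker inhibitor, a lower number a stronger inhibitor. Compound 2 `Cc1cc(C(=O)NCC2CCNCC2)nn1Cc1cc(Cl)cc2cc(-c3ccccc3)oc12` gives 20 nM. Compound 1 `Cc1cc(C(N)=O)nn1Cc1cc(Cl)cc2cc(-c3ccccc3)oc12` gives 5.01 nM.

Compound 3 stands at the highest number of the three, which in this assay means the weakest inhibitor, though its gap to compound 2 is within the scatter (a 2.0-fold higher number from compound 2 to compound 3 (0.30 log units; within the scatter)) and only its gap to compound 1 is beyond it (a 7.9-fold higher number from compound 1 to compound 3 (0.90 log units; beyond the scatter)).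

Compound 4 `Cc1cc(C(=O)NCC(O)C(F)(F)F)nn1Cc1cc(Cl)cc2cc(-c3ccccc3)oc12` differs from compound 3 in one place: (3,3,3-trifluoro-2-hydroxypropyl)carbamoyl in place of ((4-fluoropiperidin-4-yl)carbonyl)amino on an aromatic carbon. In effect the amide is turned back the way it lies in compound 2, and the ring-bearing side chain is exchanged for a short open chain carrying a hydroxyl and a trifluoromethyl group.

Within the data shown here, two measured steps bear on this. From compound 1 to compound 2, placing a substituent on the amide nitrogen gave a 4.0-fold higher number from compound 1 to compound 2 (0.60 log units; beyond the scatter), a modest loss. From compound 2 to compound 3, reversing the amide gave a 2.0-fold higher number from compound 2 to compound 3 (0.30 log units; within the scatter). Undoing that reversal in compound 4 is therefore expected to bring the number back near that of compound 2, with the new chain adding uncertainty in either direction. The expected step is a 2.7-fold lower number from compound 3 to compound 4 (0.42 log units; beyond the scatter). Compound 4 is estimated at 15 nM, within 5 nM to 50 nM.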

Compound 4, half-maximal inhibitory concentration: 25.1 nM
Compound 4: middle estimate off by 1.7-fold (0.22 log units), on the low side; the range from low to high includes it.
By their numbers in this assay, from the lowest: compound 1; then compounds 2, 4 and 3 (each within the scatter of the next).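

In this assay, the open chain of compound 4 stands where the ring-bearing side chains stood, and no change can be read from it: a 1.6-fold lower number from compound 3 to compound 4 (0.20 log units; within the scatter) and a 1.3-fold higher number from compound 2 to compound 4 (0.10 log units; within the scatter). At this carbon of the five-membered aromatic ring, then, a piperidine ring is not required to stay at this level, since a side chain with no ring and a very different set of atoms gives a number that cannot be told apart from those of compound 2 and compound 3. The clear gap remains the one to the unsubstituted carbamoyl, with a 5.0-fold higher number from compound 1 to compound 4 (0.70 log units; beyond the scatter), so compound 4 joins compound 2 and compound 3 in lying beyond the scatter from compound 1, and none of the three larger side chains matches it.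

Still open, going by these compounds, is whether a plain methyl or ethyl group on the amide nitrogen would stay close to compound 1 or join the other three, and whether the hydroxyl or the trifluoromethyl group of compound 4 matters on its own, as a simple propyl chain would help to show. Nothing available explains why such different side chains give such similar numbers.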